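Pyridine core with two hydroxyphenyl groups: an untested isomer

The source may report more compounds than this note shows. Statements on the series, on what has been measured and on what is new or still open speak of the compounds shown alone.

Measured compounds:
Compound 1, `Oc1cccc(-c2cc(-c3cccs3)cc(-c3ccccc3O)n2)c1`: 83.2%
Compound 2, `Oc1ccc(-c2cc(-c3cccs3)cc(-c3ccccc3O)n2)cc1`: 72.2%
Compound 3, `Oc1cccc(-c2cc(-c3cccnc3)cc(-c3ccccc3O)n2)c1`: 1.9%

These three compounds were tested in an assay on isolated protein for inhibition of DNA topoisomerase 1 (Homo sapiens), with a stated time of 30 min, tested at 100 uM; on this read-out higher numbers stand for a stronger effect at the one concentration tested and lower numbers for a weaker effect. Compound 1 and compound 2 share a core and differ by 4-hydroxyphenyl in place of 3-hydroxyphenyl on an aromatic carbon; this gave a number 11 percentage points lower from compound 1 to compound 2 (beyond the scatter). Compound 3 differs from compound 1 by pyridin-3-yl in place of thiophen-2-yl on an aromatic carbon, which gave a number 81.3 percentage points lower from compound 1 to compound 3 (beyond the scatter), leaving compound 3 with the lowest number of the three.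

Compound 4, `Oc1ccc(-c2cc(-c3cccnc3)cc(-c3ccccc3O)n2)cc1`, has not been measured. It differs from compound 3 by 4-hydroxyphenyl in place of 3-hydroxyphenyl on an aromatic carbon. This is the same kind of change as that from compound 1 to compound 2, but the surroundings are not identical: in the earlier pair the place was meta to a thiophen-2-yl group, here it is meta to a pyridin-3-yl group. Because compound 3 already gives 1.9%, there is little room for a further drop, so the step is expected to be small, a number 0.1 percentage points higher from compound 3 to compound 4 (within the scatter), beside the modest one seen earlier. Compound 4 is therefore estimated at 2%, most likely between -5% and 12%.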

Compound 4, a percentage reported as inhibition, at one concentration (the size of the read-out at that concentration, not a potency): 1.5%
Estimate against measurement, compound 4: 0.5 percentage points above; the range from low to high includes it.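

In this assay, 4-hydroxyphenyl in place of 3-hydroxyphenyl gave a number 0.4 percentage points lower from compound 3 to compound 4 (within the scatter), and set beside the earlier step this change carries over without a difference that can be told apart: the same change on two cores in this assay, a number 11 percentage points lower (beyond the scatter) from compound 1 to compound 2 and a number 0.4 percentage points lower (within the scatter) from compound 3 to compound 4, 10.6 percentage points apart, within the scatter of two such steps. Pyridin-3-yl in place of thiophen-2-yl also carries over, giving a number 70.7 percentage points lower from compound 2 to compound 4 (beyond the scatter), a large drop on both cores: the same change on two cores in this assay, a number 81.3 percentage points lower (beyond the scatter) from compound 1 to compound 3 and a number 70.7 percentage points lower (beyond the scatter) from compound 2 to compound 4, 10.6 percentage points apart, within the scatter of two such steps. For the compounds shown here, this does not show that either change would behave alike on other cores, since there are only two cores and one tested concentration, and compound 3 and compound 4 both lie so close to the bottom of the read-out that little room remains to see any further fall.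

The compounds shown leave open whether the high numbers belong to thiophen-2-yl alone or would also appear with a furan-2-yl or plain phenyl group in its place. They also leave open what a methoxy group or an amine would do in place of the moved hydroxyl.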